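Does a Longer Chain Shift the Number?

The source may report more compounds than this note shows. Statements on the series, on what has been measured and on what is new or still open speak of the compounds shown alone.

Three compounds share one core and differ only in the chain carried on an oxygen. In a functional assay (brain) for inhibition, with Rattus norvegicus as the target (a lower number here means a stronger inhibitor, a higher number a weaker inhibitor), compound 1 (`CCCCCCCCCCOC1=C(O)OC(C(O)CO)C1=O`) gives 13000 nM while compound 2 (`CCCCCCCCCCCCOC1=C(O)OC(C(O)CO)C1=O`) gives 54000 nM and compound 3 (`CCCCCCCCCCCCCCCCCOC1=C(O)OC(C(O)CO)C1=O`) gives 11000 nM as its reading. Compound 3 therefore sits level with compound 1 and under compound 2.

Compound 4 (`CCCCCCCCCCCCCCCCCCCCCOC1=C(O)OC(C(O)CO)C1=O`) lengthens the chain of compound 3 once more: butyl in place of hydrogen on a saturated chain carbon, ten or more bonds along the chain from an oxygen on an unsaturated carbon.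

Earlier lengthenings show no steady trend. The first raised the number (a 4.2-fold higher number from compound 1 to compound 2 (0.62 log units; beyond the scatter)), the next brought it back down (a 4.9-fold lower number from compound 2 to compound 3 (0.69 log units; beyond the scatter)), and the whole span stayed within the scatter (a 1.2-fold lower number from compound 1 to compound 3 (0.07 log units; within the scatter)). With modest steps pointing both ways, no direction can be carried forward, so the expected change is none beyond the scatter (a 1.3-fold higher number from compound 3 to compound 4 (0.10 log units; within the scatter)). Compound 4 is estimated at 14000 nM (expected range 4000 nM to 50000 nM).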

Compound 4, half-maximal inhibitory concentration: 11000 nM
The estimate for compound 4 lay 1.3-fold (0.10 log units) above the measured number, and the stated range covers the measured number.
By their numbers in this assay, from the lowest: compounds 3, 4 and 1 (each within the scatter of the next); then compound 2.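

In this assay, butyl on this saturated chain carbon gives no change at the digits printed from compound 3 to compound 4 (within the scatter), so a further lengthening this far along the chain leaves the number unmoved. The two longer chains now agree: compound 4 shows the same gap to compound 2 as compound 3 did (a 4.9-fold lower number from compound 2 to compound 4 (0.69 log units; beyond the scatter)), and it stays level with the shorter chain of compound 1 (a 1.2-fold lower number from compound 1 to compound 4 (0.07 log units; within the scatter)). Among these four compounds, chain length therefore shows no steady trend, compound 2 is the only one set apart, and nothing available accounts for that exception.

On these data alone, whether an amine or a carboxylic acid on this saturated chain carbon would shift the number remains open. So does the effect of a chain shorter than that of compound 1.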